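The compounds below may be only part of what the source reports. "The series", "measured", "known", "first", "only" and "open" are said of these compounds alone.

Compound 1 `Cc1ccc(-c2noc(COc3ccc(CCC(=O)O)cc3)n2)cc1`: 300 nM
Compound 2 `O=C(O)CCc1ccc(OCc2ncc(-c3cccc(F)c3)o2)cc1`: 1070 nM

Of the compounds shown here, two have been measured in a functional assay on CHO cells for agonist activity at Free fatty acid receptor 1 (Homo sapiens), read by FLIPR and calcium flux, in the presence of a further agent that is not named here; a lower number here means that less compound is needed, a higher number that more compound is needed for the effect. Compound 1 gives 300 nM, the lower of the two numbers, while compound 2 gives 1070 nM, a gap beyond the scatter. Compound 3 `O=C(O)CCc1ccc(OCc2nc(-c3cccs3)no2)cc1` has not been measured. It differs from compound 1 in one place: thiophen-2-yl in place of 4-methylphenyl on an aromatic carbon. For the measured compounds named here, no measured pair shows this change, so the step from compound 1 to compound 3 is expected to be small, tending toward a somewhat higher number, as a 1.7-fold higher number from compound 1 to compound 3 (0.22 log units; within the scatter). Compound 3 is therefore estimated at 500 nM, within a range of 200 nM to 1500 nM.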

Compound 3, half-maximal effective concentration: 2570 nM
Beside the measured number, compound 3's estimate is 5.1-fold (0.71 log units) below it; measured number above the stated range.
By their numbers in this assay, from the lowest: compound 1; then compound 2; then compound 3.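

The position between two ring nitrogen atoms tolerates this exchange poorly in this assay and the change is not neutral: thiophen-2-yl in place of 4-methylphenyl gives (an 8.6-fold higher number from compound 1 to compound 3 (0.93 log units; beyond the scatter)), a step beyond the scatter. So the group on this aromatic carbon clearly affects the number, which the earlier compounds, differing in more than one place, could not show. Nothing available accounts for the size of this step.

Going by these compounds, it remains open whether the methyl or the ring itself matters. Phenyl, 4-chlorophenyl or furan-2-yl at this position would help separate the two.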